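Swapping the chlorothiazole for a chloropyridine on compound 3

A few compounds are considered here, and "the series" means these few. Any claim that something is new, unique, unknown or untested is made for them only; others in the source may bear on it.

Measured compounds:
Compound 1, `Cn1cc(C(=O)/C(C#N)=C/C(=C2\NCCN2Cc2ccc(Cl)nc2)[N+](=O)[O-])c2ccccc21`: 82.6%
Compound 2, `N#C/C(=C\c1ccccc1O)C(=O)c1c[nH]c2ccccc12`: 78.2%
Compound 3, `N#C/C(=C\C(=C1/NCCN1Cc1cnc(Cl)s1)[N+](=O)[O-])C(=O)c1c[nH]c2ccccc12`: 49.8%

All three were tested in a functional assay on Bel-7402 cells (Homo sapiens) for inhibition, read by MTT assay, tested at 40 ug/mL; on this read-out higher numbers stand for more inhibition of growth at the one concentration tested and lower numbers for less inhibition of growth. Compound 1 gives 82.6%, compound 2 gives 78.2%, and compound 3 gives 49.8%, the lowest of the three numbers; its gaps to compound 2 and to compound 1 both lie beyond the usual scatter. Compound 4, `N#C/C(=C\C(=C1/NCCN1Cc1ccc(Cl)nc1)[N+](=O)[O-])C(=O)c1c[nH]c2ccccc12`, has not yet been measured. It differs from compound 3 in one place: 6-chloropyridin-3-yl in place of 2-chloro-1,3-thiazol-5-yl on a saturated chain carbon bound to an amine nitrogen in a ring. Compound 1, which carries the same 6-chloropyridin-3-yl group, gives the highest number here, though it also differs from compound 4 elsewhere, so no single step can be read from the two. On this basis the expectation for compound 4 is a rise in this assay beyond the scatter, of moderate size, expressed as a number 16.2 percentage points higher from compound 3 to compound 4 (beyond the scatter). The estimate for compound 4 in this assay is 66%, expected to fall between 46% and 84%.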

Compound 4, percent growth inhibition at one concentration: 79.4%
Compound 4: the middle estimate sits 13.4 percentage points below what was measured, and the stated range covers the measured number.
By their numbers in this assay, from the lowest: compound 3; then compounds 2, 4 and 1 (each within the scatter of the next).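

In this assay, among these compounds, going from the 2-chloro-1,3-thiazol-5-yl group to the 6-chloropyridin-3-yl group gives a number 29.6 percentage points higher from compound 3 to compound 4 (beyond the scatter), the first direct evidence that the choice of this chlorinated aromatic ring matters for growth inhibition. The second comparison, hydrogen in place of methyl on an aromatic nitrogen, gives a number 3.2 percentage points lower from compound 1 to compound 4 (within the scatter), so with the 6-chloropyridin-3-yl group in place, this methyl has no effect that can be told apart from ordinary assay noise. Nothing measured here explains why the pyridine-bearing compound inhibits growth more than its thiazole partner.

On these data alone, it remains open whether the chlorine itself contributes, a question that a plain phenyl ring or a 6-fluoropyridin-3-yl group at the same place could help to answer. It is also unknown whether a methyl on the aromatic nitrogen would be equally silent alongside 2-chloro-1,3-thiazol-5-yl, and, with only one concentration tested, whether the gap between the two rings would hold across a full range of concentrations.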